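The source may hold more compounds than are shown below. What is called first, only, known or untested is meant among the compounds shown, and "the series" means these compounds.

Measured compounds:
- compound 1, `Cc1cc(Nc2ccn(Cc3cccc4ccccc34)n2)n2nc(SCc3ccc(Br)cc3)nc2n1`, 4310 nM
- compound 2, `Cc1cc(Nc2cc(-c3ccccc3)[nH]n2)n2nc(SCc3c(Cl)cccc3Cl)nc2n1`, 3230 nM
- compound 3, `CCCCCc1c(C)nc2nc(SCc3ccc(Cl)cc3)nn2c1Nc1cc(-c2ccccc2)[nH]n1`, 6390 nM

All three numbers come from a functional assay on MCF7 cells (Homo sapiens) for inhibition, read by MTT assay, with a stated time of 72 h; a lower number here means a stronger inhibitor, a higher number a weaker inhibitor. Compound 2 gives the lowest of the three numbers, but its distance to compound 1 and to compound 3 lies within the scatter of the assay, so the three compounds cannot be separated on these data and none of them can be called the most or least active. Within the data shown here, the series so far spans a narrow band of values with different amine and sulfanyl substituents on the shared core.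

Compound 4, `Cc1cc(Nc2cc(-c3ccccc3)[nH]n2)n2nc(SCc3ccc(F)cc3)nc2n1`, has not yet been measured. It differs from compound 2 in one place:

4-fluorophenyl in place of 2,6-dichlorophenyl on a saturated chain carbon bound to a sulfur

Among the measured compounds shown here, no step between two measured compounds isolates this change, so there is no direct guide to its effect. Given how close the three measured numbers sit, the expected step in this assay from compound 2 to compound 4 is small, a 1.4-fold higher number from compound 2 to compound 4 (0.14 log units; within the scatter), with no confident direction beyond the scatter. Compound 4 is therefore estimated at 4500 nM, with a range of 1800 nM to 11000 nM.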

Compound 4, half-maximal inhibitory concentration: 4020 nM
Beside the measured number, compound 4's estimate is 1.1-fold (0.05 log units) above it, and the stated range covers the measured number.
By their numbers in this assay, from the lowest: compounds 2, 4, 1 and 3 (each within the scatter of the next).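

Working from this assay, replacing 2,6-dichlorophenyl with 4-fluorophenyl on a saturated chain carbon bound to a sulfur gives a 1.2-fold higher number from compound 2 to compound 4 (0.10 log units; within the scatter), the first comparison in the series that isolates a single place. On this pair the two aryl groups cannot be told apart, so the change in ring substitution, including the loss of both chlorine atoms and the entry of one fluorine, leaves no separable effect on the read-out. No measured evidence is available to explain this result.

From the compounds shown here alone, whether an unsubstituted benzyl, a simple longer chain, or a benzyl ring carrying a carboxylic acid or an amine would give a separable value at this position remains open. Also open, going by these compounds, is whether the same result would hold on a core with different substituents elsewhere.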